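The source may hold more compounds than are shown below. What is called first, only, known or untested is meant among the compounds shown, and "the series" means these compounds.

In a functional assay on M21 cells (Homo sapiens) for antiproliferative activity, read by sulforhodamine B assay, with a stated time of 48 h (on this read-out higher numbers stand for weaker inhibition and lower numbers for stronger inhibition), compound 3 `O=C1NCCN1c1ccc(S(=O)(=O)Nc2ccc(OC(F)F)cc2)cc1` gives 410 nM and compound 1 `CCc1ccc(NS(=O)(=O)c2ccc(N3CCNC3=O)cc2)cc1` gives 480 nM as its nearest neighbour on the numbers shown. That gap is a 1.2-fold lower number from compound 1 to compound 3 (0.07 log units; within the scatter) and so neither stands clear of the other. Compound 2 `CC(C)(C)c1ccc(NS(=O)(=O)c2ccc(N3CCNC3=O)cc2)cc1` reads > 1000 nM as a limit of the assay and not a number. Against that limit the series shows an at least 2.0-fold higher number from compound 1 to compound 2 (0.31 log units; beyond the scatter) and also an at least 2.4-fold lower number from compound 2 to compound 3 (0.38 log units; beyond the scatter) on the same substituent.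

Compound 4 `COc1ccc(NS(=O)(=O)c2ccc(N3CCNC3=O)cc2)cc1` comes next, with methyl in place of difluoromethyl on an oxygen on an aromatic ring as the counted change: methyl in place of difluoromethyl on an oxygen on an aromatic ring, that is, difluoromethoxy to methoxy. Going by the values given here, no measured step covers this exact swap. Among the compounds with values here, the nearest guide is the swap from ethyl to difluoromethoxy, a 1.2-fold lower number from compound 1 to compound 3 (0.07 log units; within the scatter) in all, while tert-butyl is the only group among the three to stand off from the others. No step beyond the scatter is therefore expected in this assay for this change. The step expected is a 1.1-fold higher number from compound 3 to compound 4 (0.04 log units; within the scatter) on this reasoning, which rests on few data. For compound 4 the estimate is 450 nM as the expected value, with an expected range from 200 nM to 1000 nM for a repeated measurement.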

Compound 4, half-maximal inhibitory concentration: 580 nM
Beside the measured number, compound 4's estimate is 1.3-fold (0.11 log units) below it, and the stated range covers the measured number.
By their numbers in this assay, from the lowest: compounds 3, 1 and 4 (each within the scatter of the next). At a limit, above all of these: compound 2.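

In this assay, methyl in place of difluoromethyl on an oxygen on an aromatic ring gives a 1.4-fold higher number from compound 3 to compound 4 (0.15 log units; within the scatter), so the fluorine atoms of the difluoromethoxy group are not required to hold this level, and methoxy also stays level with ethyl, at a 1.2-fold higher number from compound 1 to compound 4 (0.08 log units; within the scatter). Against tert-butyl the read-out gives an at least 1.7-fold lower number from compound 2 to compound 4 (0.23 log units; that floor lies within the scatter), so methoxy, unlike difluoromethoxy, is not shown to stand clear of tert-butyl on an aromatic carbon. The value of compound 2 is a limit of the assay and not a number: the limit of > 1000 nM in this assay, at which 1 of the 4 values shown sits.

Ethyl, difluoromethoxy and methoxy on an aromatic carbon form one level on these values, with compound 2 as the only compound that goes against this pattern, and the true size of the steps to compound 2 stays open. Also open, as far as these compounds go, is whether that level holds for an amine, a carboxylic acid, a nitrile or a longer chain such as propoxy on the same aromatic carbon, or whether any such group separates from the level in either direction.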